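Adding a Thiophene Arm to the Methylamino Group

The source may hold more compounds than are shown below. What is called first, only, known or untested is meant among the compounds shown, and "the series" means these compounds.

The measured compounds and their values:
- compound 1 `Nc1nc(Cl)c(-c2nccs2)c(N[C@@H]2C[C@H](CO)[C@@H](O)[C@H]2O)n1` gives > 25000 nM in an ADME assay on cells (Homo sapiens) for cytotoxicity, read by polymerase chain reaction, with a stated time of 3 days (a higher number here means that more compound is tolerated, a lower number that less compound is tolerated), which is a limit of the assay and not a number.
- compound 2 `Nc1nc(Cl)c(-c2nc3ccccc3o2)c(N[C@@H]2C[C@H](CO)[C@@H](O)[C@H]2O)n1` gives 12000 nM in this assay.
- compound 3 `CNc1nc(C)c(-c2nc3ccccc3s2)c(N[C@@H]2C[C@H](CO)[C@@H](O)[C@H]2O)n1` gives > 25000 nM in this assay, again a limit and not a number.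

Compound 3 therefore stands at the top of what the assay can report, sharing that position with compound 1, as the limit of > 25000 nM in this assay, at which 2 of the 3 values shown sit, records. Compound 4 `Cc1nc(NCc2cccs2)nc(N[C@@H]2C[C@H](CO)[C@@H](O)[C@H]2O)c1-c1nc2ccccc2s1` differs from it in one place: thiophen-2-yl in place of hydrogen on a saturated chain carbon bound to a nitrogen on an aromatic ring.

For the measured compounds named here, only one measured step exists, an at least 2.0-fold lower number from compound 1 to compound 2 (0.31 log units; beyond the scatter), and it exchanges one ring for another on the aromatic carbon, not on the methylamino group. Going by the values given here, no measured step bears on the change from compound 3 to compound 4. Where an aromatic ring did grow, the number fell modestly; a similar or smaller effect, or none beyond the scatter, is therefore the expectation here. Compound 4 is expected to give about 18000 nM, between 6000 nM and 25000 nM, meaning an expected step of an at least 1.3-fold lower number from compound 3 to compound 4 (0.14 log units; that floor lies within the scatter).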

Compound 4, half-maximal cytotoxic concentration: 6000 nM
Compound 4: middle estimate off by 3.0-fold (0.48 log units), on the high side; the measured number falls inside the stated range.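

In this assay, thiophen-2-yl in place of hydrogen on a saturated chain carbon bound to a nitrogen on an aromatic ring gives an at least 4.1-fold lower number from compound 3 to compound 4 (0.61 log units; beyond the scatter). Among the earlier compounds, the one readable step was a ring exchange on an aromatic carbon, so this is the first sign that a change at the methylamino group can also lower the number. Compound 3 gives > 25000 nM, which is a limit and not a number.

As far as these compounds go, what stays open is whether this result depends on thiophen-2-yl itself or whether other groups in the same place, such as phenyl or a plain propyl chain, would lower the number too. From the compounds shown here alone, it is also open whether the same change would have a similar effect with the chlorine-bearing core of compound 1.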